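The compounds below may be only part of what the source reports. "The series", "measured", "known", "first", "only" and "open" are said of these compounds alone.

Four compounds share one core and are compared in a functional assay on HeLa cells (Homo sapiens) for antiproliferative activity, read by MTT assay, with a stated time of 48 h; on this read-out lower numbers stand for stronger inhibition of growth and higher numbers for weaker inhibition of growth. Compound 3 `CCOC(=O)c1sc2ccc(NCc3nc[nH]c3C)cc2c1NC(=O)c1ccc(OC)cc1` gives 8220 nM in this assay, the lowest of the three numbers measured. Within the data shown here, compound 1 `CCOC(=O)c1sc2ccc(NCc3c[nH]cn3)cc2c1NC(=O)c1ccc(C)cc1` gives 11700 nM, within the scatter of compound 3, while compound 2 `CCOC(=O)c1sc2ccc(NCc3nc[nH]c3C)cc2c1NC(=O)c1ccccc1` gives 23300 nM, the only value beyond it. Among the measured compounds shown here, the one measured change on the six-membered aromatic ring of carbon only is a 2.8-fold lower number from compound 2 to compound 3 (0.45 log units; beyond the scatter). Compound 4 `CCOC(=O)c1sc2ccc(NCc3nc[nH]c3C)cc2c1NC(=O)c1ccc(C)cc1` carries methyl in place of methoxy on an aromatic carbon. For the measured compounds named here, no measured step covers exactly this change, but compound 1, which bears the same methyl on that ring together with a different group elsewhere, sits close to compound 3. Compound 4 is therefore expected to give 10000 nM, between 5000 nM and 20000 nM. The expected step is a 1.2-fold higher number from compound 3 to compound 4 (0.09 log units; within the scatter), with no clear direction.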

Compound 4, concentration for 50% growth inhibition: 11400 nM
Estimate against measurement, compound 4: 1.1-fold (0.06 log units) below; the measured number falls inside the stated range.
By their numbers in this assay, from the lowest: compounds 3, 4, 1 and 2 (each within the scatter of the next, the first and the last beyond it).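

In this assay, methoxy and methyl at this place on the six-membered aromatic ring, para to a large group, cannot be told apart (a 1.4-fold higher number from compound 3 to compound 4 (0.14 log units; within the scatter)). Methyl in place of hydrogen there also passes the scatter, if only just (a 2.0-fold lower number from compound 2 to compound 4 (0.31 log units; beyond the scatter)), so both groups tried differ from hydrogen. The methyl on the other aromatic carbon, away from this ring, shows no measurable effect (a 1.0-fold lower number from compound 1 to compound 4 (0.01 log units; within the scatter)). No measurement here explains the size of these steps. On these data alone, whether an amine or a carboxylic acid at this place would keep, lose or improve growth inhibition stays open.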